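Ester removal at the allylic alcohol of compound 1

The source may report more compounds than this note shows. Statements on the series, on what has been measured and on what is new or still open speak of the compounds shown alone.

Measured compounds:
- compound 1, `COC(=O)/C(=C/Cn1c(-c2ccccc2)ncc(NC(=O)OCc2ccccc2)c1=O)COC(=O)c1ccc([N+](=O)[O-])cc1`: in a functional assay on cells (Macrophage cell line, Homo sapiens) for inhibition (a lower number here means a stronger inhibitor, a higher number a weaker inhibitor), compound 1 gives 3.6 ug/mL
- compound 2, `COC(=O)/C(=C/Cn1c(-c2ccccc2)ncc(NC(=O)N2CCN(C(C)=O)CC2)c1=O)COC(C)=O`: in this assay compound 2 gives 16 ug/mL

Of the two measured compounds, compound 1 gives the lower number in this assay, and the gap to compound 2 lies beyond the usual scatter. Compound 2 differs from compound 1 in more than one place, so no single step can be read from the pair.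

Compound 3, `COC(=O)/C(=C/Cn1c(-c2ccccc2)ncc(NC(=O)OCc2ccccc2)c1=O)CO`, is not yet measured. Relative to compound 1 the change is hydrogen in place of (4-nitrophenyl)carbonyl on an oxygen on a saturated carbon, leaving a hydroxy where the ester stood. Among the compounds with values here, no measured pair shows this change, so the expectation rests on the size of the group lost. A weaker inhibitor is expected, with a step of a 2.5-fold higher number from compound 1 to compound 3 (0.40 log units; beyond the scatter) in this assay that may exceed the scatter. The estimate for compound 3 in this assay is 9 ug/mL, within 2.5 ug/mL to 32 ug/mL.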

Compound 3, half-maximal inhibitory concentration: 0.78 ug/mL
Compound 3: middle estimate off by 12-fold (1.06 log units), on the high side; measured number outside the range, below it.
By their numbers in this assay, from the lowest: compound 3; then compound 1; then compound 2.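

In this assay, within the data shown here, the first single-place step is a 4.6-fold lower number from compound 1 to compound 3 (0.66 log units; beyond the scatter) and it runs toward stronger inhibition, so the (4-nitrophenyl)carbonyl on the oxygen on a saturated carbon is not required for activity. At this position, a free hydroxy serves better than this ester, and the loss of 11 heavy atoms, including an aromatic ring, costs nothing in this assay. Nothing on hand bears on the reason for this step.

Among these compounds, it remains open whether the gain belongs to the free hydroxy itself or to the loss of this particular aromatic ester, since a smaller acetyl ester is seen only in compound 2, which also differs elsewhere. A methyl ether, an amine or a carboxylic acid at this carbon would help separate these readings.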